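The source may report more compounds than this note shows. Statements on the series, on what has been measured and on what is new or still open speak of the compounds shown alone.

Measured in a functional assay on HL-60 cells (Homo sapiens) for antiproliferative activity; on this read-out higher numbers stand for weaker inhibition and lower numbers for stronger inhibition:
Compound 1 `CCOC(=O)c1ccc(Oc2ccc(OC)cc2)cc1`: > 20000 nM
Compound 2 `CCOC(=O)c1ccc(Oc2ccc(OC)c(F)c2)cc1`: 3500 nM

The entry for compound 1 is a limit of the assay and not a number: > 20000 nM. For the measured compounds named here, compound 2 therefore holds the only true number so far, 3500 nM.

Next comes compound 3 `CCOC(=O)c1ccc(Oc2ccc(OC)c(OC)c2)cc1`, which carries methoxy in place of fluoro on an aromatic carbon, ortho to a methoxy group and meta to a large group: methoxy in place of fluoro on an aromatic carbon. Going by the values given here, one measured step bears on this carbon: an at least 5.7-fold lower number from compound 1 to compound 2 (0.75 log units; beyond the scatter), where fluoro replaced hydrogen. That step shows that substitution here can move the read-out in this assay beyond the scatter. It does not compare fluoro with methoxy, so the direction of the new step is poorly constrained. The working expectation is that compound 3 keeps part of the gain seen in an at least 5.7-fold lower number from compound 1 to compound 2 (0.75 log units; beyond the scatter), with a small move towards higher numbers or none beyond the scatter. The estimated change is a 1.7-fold higher number from compound 2 to compound 3 (0.23 log units; within the scatter). For compound 3 the expected value is 6000 nM, with an estimated range of 1500 nM to 20000 nM.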

Compound 3, half-maximal inhibitory concentration: > 20000 nM
Compound 3 ended at the assay's limit (the forecaster's own chance of this, stated with the estimate: 25%); at least 3.3-fold (0.52 log units) between middle value and limit.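

Methoxy in place of fluoro on this aromatic carbon, ortho to a methoxy group, gives an at least 5.7-fold higher number from compound 2 to compound 3 (0.75 log units; beyond the scatter), so in this assay the gain at this position depends on which group enters and does not follow from substitution as such. Compound 3 gives a limit of the assay and not a number: > 20000 nM. The step from hydrogen to methoxy at this carbon cannot be read, because both entries are limits: the limit of > 20000 nM in this assay, at which 2 of the 3 values shown sit.

Going by these compounds, with only fluoro and methoxy compared at this carbon, it remains open whether the read-out tracks the size of the entering group, its hydrogen-bond acceptor count or some other feature, and chloro, hydroxy or a nitrile there would help to separate these possibilities. On these data alone, it is also open whether fluoro keeps its gain when other parts of the shared core change, for example with a carboxylic acid or an amide in place of the ethyl ester.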